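A few compounds are considered here, and "the series" means these few. Any claim that something is new, unique, unknown or untested is made for them only; others in the source may bear on it.

Among the compounds with values here, compound 2 `CCOc1ncc(-c2nc(C(F)(F)F)sc2N2CCN(C(=O)Cn3nc(C)cc3C)[C@H](C)C2)cn1` stands at the high end of the two numbers measured so far: in a functional assay on U2OS cells for antagonist activity at C-X-C chemokine receptor type 3 (Homo sapiens), read by beta-arrestin recruitment (on this read-out higher numbers stand for weaker inhibition and lower numbers for stronger inhibition), compound 2 gives 87 nM, whereas compound 1 `CCOc1ncc(-c2nc(C(F)(F)F)sc2N2CCN(C(=O)Cn3ccc4cnccc43)[C@H](C)C2)cn1` gives 23 nM. Within the data shown here, the only step between measured compounds is a 3.8-fold higher number from compound 1 to compound 2 (0.58 log units; beyond the scatter), the exchange of one aromatic group for another on a saturated chain carbon bound to a carbonyl carbon. Compound 3 `CCOc1ncc(-c2nc(C(F)(F)F)sc2N2CCN(C(=O)Cn3nc(C)nc3C)[C@H](C)C2)cn1` carries 3,5-dimethyl-1H-1,2,4-triazol-1-yl in place of 3,5-dimethyl-1H-pyrazol-1-yl on a saturated chain carbon bound to a carbonyl carbon, a change at the same place but far narrower than the one already measured. Among the measured compounds shown here, no measured step shows how 3,5-dimethyl-1H-1,2,4-triazol-1-yl compares with 3,5-dimethyl-1H-pyrazol-1-yl here, so compound 3 is expected to move from compound 2 by a 1.3-fold higher number from compound 2 to compound 3 (0.10 log units; within the scatter), a step within the usual scatter with a slight lean toward a higher number in this assay. Compound 3 is therefore estimated at 110 nM, in a range from 40 nM to 300 nM.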

Compound 3, half-maximal inhibitory concentration in the C-X-C chemokine receptor type 3 assay: 173 nM
Compound 3: the middle estimate sits 1.6-fold (0.20 log units) below what was measured, within the range that was stated.
By their numbers in the C-X-C chemokine receptor type 3 assay, from the lowest: compound 1; then compounds 2 and 3 (each within the scatter of the next).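

In the C-X-C chemokine receptor type 3 assay, 3,5-dimethyl-1H-1,2,4-triazol-1-yl in place of 3,5-dimethyl-1H-pyrazol-1-yl on a saturated chain carbon bound to a carbonyl carbon gives a 2.0-fold higher number from compound 2 to compound 3 (0.30 log units; within the scatter), so this narrow exchange cannot be told apart from repeat measurement there. The same exchange does register in a physicochemical assay for lipophilicity, at pH 7.4; on this read-out higher numbers stand for higher lipophilicity and lower numbers for lower lipophilicity: the measured distribution coefficient of compound 2, 3.7, and of compound 3, 2.8, a number 0.90 log units lower (beyond the scatter). In the physicochemical assay compound 2 gives 3.7 and compound 3 gives 2.8. The group with two aromatic rings stays clearly apart in the C-X-C chemokine receptor type 3 assay, with a 7.5-fold higher number from compound 1 to compound 3 (0.88 log units; beyond the scatter).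

The compounds shown leave open whether a lower distribution coefficient can be had at the level of inhibition that the group with two aromatic rings gives. They also leave open how a primary amine or a carboxylic acid in place of one methyl on the five-membered ring would behave in the C-X-C chemokine receptor type 3 assay.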